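Cytotoxicity in Rat Muscle Cells: Three Analogues and a Fourth

The source may hold more compounds than are shown below. What is called first, only, known or untested is meant among the compounds shown, and "the series" means these compounds.

Compound 1 `OC(c1ccc(Cl)cc1)(c1cncnc1)c1ccccc1F`: in an ADME assay on L6 cells (Rattus norvegicus) for cytotoxicity, read by resazurin assay, with a stated time of 72 h (on this read-out higher numbers stand for weaker inhibition and lower numbers for stronger inhibition), compound 1 gives > 100000 nM, a limit of the assay.
Compound 2 `OC(c1ccc(Cl)cc1)(c1cncnc1)c1cccc(F)c1`: in this assay compound 2 gives > 100000 nM, also a limit.
Compound 3 `OC(c1ccc(Cl)cc1)(c1cccnc1)c1ccccc1F`: in this assay compound 3 gives > 100000 nM, again a limit.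

All three compounds share one core and differ at a single saturated chain carbon. Compound 1 and compound 2 differ by 3-fluorophenyl in place of 2-fluorophenyl on a saturated chain carbon bound to two aromatic carbons and an oxygen on a saturated carbon, and that step, a step that the two limits leave unreadable from compound 1 to compound 2, cannot be sized because of the limit of > 100000 nM in this assay, at which 3 of the 3 values shown sit. Compound 1 and compound 3 differ by pyridin-3-yl in place of pyrimidin-5-yl on a saturated chain carbon bound to two aromatic carbons and an oxygen on a saturated carbon, giving a step that the two limits leave unreadable from compound 1 to compound 3, which is likewise unreadable. Compound 4 `OC(c1ccc(Cl)cc1)(c1cccnc1)c1cccc(F)c1` has not been measured; it differs from compound 3 by 3-fluorophenyl in place of 2-fluorophenyl on a saturated chain carbon bound to two aromatic carbons and an oxygen on a saturated carbon, the same change as from compound 1 to compound 2. For compound 4 the step that the limit leaves unreadable from compound 3 to compound 4 is expected to be flat, resting on the limits reached by compound 1 and compound 2 and on compound 3 standing at > 100000 nM. Compound 4 is therefore estimated at 150000 nM in this assay.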

Compound 4, half-maximal inhibitory concentration: 66000 nM
Beside the measured number, compound 4's estimate is 2.3-fold (0.36 log units) above it; the measured number lies below the stated range.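

In this assay, putting 3-fluorophenyl in place of 2-fluorophenyl on the core of compound 3 gives an at least 1.5-fold lower number from compound 3 to compound 4 (0.18 log units; that floor lies within the scatter), and putting pyridin-3-yl in place of pyrimidin-5-yl on the core of compound 2 gives an at least 1.5-fold lower number from compound 2 to compound 4 (0.18 log units; that floor lies within the scatter). Each step is known only as a floor, so the true size could be larger, but neither is shown to go beyond the usual scatter. Whether the fluorine change acts alike on the two cores cannot be told, and the other steps cannot be read, because the values at their ends are limits: the limit of > 100000 nM in this assay, at which 3 of the 4 values shown sit.

The compounds shown leave open what an amine or a methoxy group in place of the fluorine would do in this assay. They also leave open how far below the limit any compound of this series can go.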